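Replacing the trimethoxyphenyl ring with an isopropylphenyl group

The source may hold more compounds than are shown below. What is called first, only, known or untested is meant among the compounds shown, and "the series" means these compounds.

Measured so far:
Compound 1 `COc1cccc(/C=C/C(=O)c2ccc(OCCn3cc(CN4C(=O)/C=C/C(C)(C)C/C=C(\C)CC/C=C/4C)nn3)cc2O)c1`: 1.01 ug/mL
Compound 2 `COc1cc(/C=C/C(=O)c2ccc(OCCn3cc(CN4C(=O)/C=C/C(C)(C)C/C=C(\C)CC/C=C/4C)nn3)cc2O)cc(OC)c1OC`: 1.44 ug/mL

For the measured compounds named here, in a functional assay on HepG2 cells (Homo sapiens) for antiproliferative activity (a lower number here means a stronger inhibitor, a higher number a weaker inhibitor), compound 2 holds the higher of the two numbers, but its only neighbour is compound 1, and the step of a 1.4-fold higher number from compound 1 to compound 2 (0.15 log units; within the scatter) stays within the scatter, so the two compounds cannot be ranked against each other. Compound 3 `C/C1=C\CC(C)(C)/C=C/C(=O)N(Cc2cn(CCOc3ccc(C(=O)/C=C/c4ccc(C(C)C)cc4)c(O)c3)nn2)/C(C)=C/CC1` differs from compound 2 at the same position: 4-isopropylphenyl in place of 3,4,5-trimethoxyphenyl on a double-bonded chain carbon bound to a double-bonded chain carbon. Going by the values given here, the one measured step that touches this position is the step from compound 1 to compound 2, which was within the scatter; no measured compound carries the 4-isopropylphenyl group, so nothing shows how far a change of this kind can move the number. On that basis the step to compound 3 in this assay is expected to be small, a 1.0-fold higher number from compound 2 to compound 3 (0.02 log units; within the scatter), with a wide margin either way. Compound 3 is therefore estimated at 1.5 ug/mL, in a range from 0.6 ug/mL to 4 ug/mL.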

Compound 3, half-maximal inhibitory concentration: 0.84 ug/mL
For compound 3 the middle estimate is 1.8-fold (0.25 log units) above the measured one, within the range that was stated.
By their numbers in this assay, from the lowest: compounds 3, 1 and 2 (each within the scatter of the next).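

The position on a double-bonded chain carbon bound to a double-bonded chain carbon now carries a ring without any oxygen, and in this assay the change gives a 1.7-fold lower number from compound 2 to compound 3 (0.23 log units; within the scatter) and also a 1.2-fold lower number from compound 1 to compound 3 (0.08 log units; within the scatter). Both steps stay within the scatter, so the methoxy groups of compound 1 and compound 2 can give way to 4-isopropylphenyl without the numbers separating, and the three compounds cannot be told apart here. Nothing available bears on why these numbers lie so close.

Going by these compounds, all three compounds keep a six-membered aromatic ring of carbon only at this position, so the effect of replacing that ring with a saturated cyclohexyl group stays open. Equally open, on these data alone, is whether an amine or a carboxylic acid on the ring would move the number beyond the scatter.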